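The source may report more compounds than this note shows. Statements on the series, on what has been measured and on what is new or still open speak of the compounds shown alone.

Two compounds of the series carry numbers in a toxicity assay on the whole organism (J774 cells) for cytotoxicity, with Mus musculus as the target, read by MTT assay, with a stated time of 24 h, tested at 30 uM; a lower number here means a stronger effect, a higher number a weaker effect of the compound at the concentration tested. Compound 1, `CCCCCCCCCO[C@@H]1[C@@H](N)[C@@H](OCC(O)CNCCCN)O[C@H](CN)[C@H]1OCCCCCCCCC`, gives 71.6%, which is the lowest of the two values; compound 2, `NC[C@H]1O[C@H](O[C@H]2[C@H](O)[C@@H](OCc3ccc4ccccc4c3)[C@H](N)C[C@@H]2N)[C@H](N)[C@@H](OCc2ccc3ccccc3c2)[C@@H]1O`, gives 75.9%, the nearer of the two and within the scatter of compound 1, so no order between them can be read. Compound 3, `CCCCCCCCCO[C@@H]1[C@@H](N)[C@@H](OC[C@H](O)CN)O[C@H](CN)[C@H]1OCCCCCCCCC`, remains to be measured in this assay. Compound 3 differs from compound 1 in one place: 2-amino-1-hydroxyethyl in place of 2-((3-aminopropyl)amino)-1-hydroxyethyl on a saturated chain carbon bound to an oxygen on a saturated carbon. Among the measured compounds shown here, no step between measured compounds exists to calibrate this change, so the expectation rests on the two values alone. The step from compound 1 to compound 3 in this assay is estimated to be small, a number 4.4 percentage points higher from compound 1 to compound 3 (within the scatter), leaning upward but not beyond the scatter. For compound 3 the expected value is 76%, in a range from 62% to 90%.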

Compound 3, a percentage reported as activity, at one concentration (the size of the read-out at that concentration, not a potency): 14.4%
For compound 3 the middle estimate is 61.6 percentage points above the measured one, outside the stated range (below it).
By their numbers in this assay, from the lowest: compound 3; then compounds 1 and 2 (each within the scatter of the next).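

In this assay, among the compounds shown here, this position proves highly sensitive: 2-amino-1-hydroxyethyl in place of 2-((3-aminopropyl)amino)-1-hydroxyethyl gives a number 57.2 percentage points lower from compound 1 to compound 3 (beyond the scatter), a stronger effect at the concentration tested, which the two earlier values, with no step between them, could not reveal. The change is not a simple truncation of the chain, since the entering group also has a defined stereocentre, which the computed description does not list for the leaving group. Nothing at hand explains the size of this step.

For the compounds shown here, the single step does not separate the loss of the aminopropyl portion from the contribution of the defined stereocentre. Going by these compounds, how the opposite configuration of 2-amino-1-hydroxyethyl, or a carboxylic acid or guanidine at the same place, would read in this assay also remains open.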